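The compounds below may be only part of what the source reports. "The series", "measured", "known", "first", "only" and "open" are said of these compounds alone.

Compound 1, `OCCc1cn(CCNc2nonc2/C(=N/O)Nc2ccc(F)c(Br)c2)nn1`, measured at 1170 nM.
Compound 2, `OCCCCc1cn(CCNc2nonc2/C(=N/O)Nc2ccc(F)c(Br)c2)nn1`, measured at 1080 nM.

Both readings come from an assay on isolated protein for inhibition of Indoleamine 2,3-dioxygenase 2 (Homo sapiens); on this read-out higher numbers stand for weaker inhibition and lower numbers for stronger inhibition. Compound 2 holds the lowest of the two numbers, yet the step of a 1.1-fold lower number from compound 1 to compound 2 (0.03 log units; within the scatter) lies within the scatter, so the two compounds cannot be told apart. Compound 3, `CC(C)(O)c1cn(CCNc2nonc2/C(=N/O)Nc2ccc(F)c(Br)c2)nn1`, differs from compound 2 by 1-hydroxy-1-methylethyl in place of 4-hydroxybutyl on an aromatic carbon. Among the measured compounds shown here, only the step from compound 1 to compound 2 bears on this: it swapped one hydroxyalkyl chain for another and moved the number no further than the scatter. Compound 3 is therefore expected to show a step of a 1.2-fold higher number from compound 2 to compound 3 (0.08 log units; within the scatter). The estimate for compound 3 is 1300 nM, with a range from 500 nM to 3500 nM.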

Compound 3, half-maximal inhibitory concentration: 726 nM
Compound 3: the middle estimate sits 1.8-fold (0.25 log units) above what was measured; low and high end bracket the measured number.
By their numbers in this assay, from the lowest: compounds 3, 2 and 1 (each within the scatter of the next).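

Replacing a straight hydroxyalkyl chain with the branched 1-hydroxy-1-methylethyl on this aromatic carbon gives a 1.5-fold lower number from compound 2 to compound 3 (0.17 log units; within the scatter) and a 1.6-fold lower number from compound 1 to compound 3 (0.21 log units; within the scatter) in this assay, so the three compounds cannot be told apart. The position therefore accepts a branched group as well as chains of different length, with no readable change in the number. Nothing available explains this result.
Going by these compounds, whether an amine, a carboxylic acid or a plain methyl at this carbon would move the number beyond the scatter remains open.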